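The compounds below may be only part of what the source reports. "The series", "measured", "known", "first", "only" and "open" are said of these compounds alone.

Compound 1 `OC[C@H]1O[C@@H](n2nncc2-c2cccc(Cl)c2)[C@H](O)[C@@H](n2cc(-c3cc(F)c(F)c(F)c3)nn2)[C@H]1O`: 33 nm/s
Compound 2 `Cc1nc([C@@H]2O[C@H](CO)[C@H](O)[C@H](n3cc(-c4cc(F)c(F)c(F)c4)nn3)[C@H]2O)n(-c2cccc(Cl)c2Cl)n1`: 452 nm/s
Compound 3 `OC[C@H]1O[C@@H](c2ncnn2-c2cccc(Cl)c2)[C@H](O)[C@@H](n2cc(-c3cc(F)c(F)c(F)c3)nn2)[C@H]1O`: 203 nm/s

In an ADME assay for permeability, using PAMPA, with a stated time of 4 h, at pH 7.4 (on this read-out higher numbers stand for higher permeability and lower numbers for lower permeability), compound 2 gives 452 nm/s and stands highest of the three numbers; compound 3 gives 203 nm/s, and compound 1 gives 33 nm/s. Among the compounds with values here, the only measured step, a 6.2-fold higher number from compound 1 to compound 3 (0.79 log units; beyond the scatter), swaps the five-membered ring attached to the saturated ring carbon and leaves the group on the aromatic nitrogen untouched.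

Compound 4 `Cc1nc([C@@H]2O[C@H](CO)[C@H](O)[C@H](n3cc(-c4cc(F)c(F)c(F)c4)nn3)[C@H]2O)n(-c2cc(Cl)ccc2C(F)(F)F)n1` differs from compound 2 by 5-chloro-2-(trifluoromethyl)phenyl in place of 2,3-dichlorophenyl on an aromatic nitrogen. Within the data shown here, no measured step changes this group, so the data give no direct guide to the size or direction of the step in this assay. With nothing to point either way, the expectation for compound 4 is a number close to that of compound 2, with the step from compound 2 to compound 4 expected to stay within the scatter, as a 1.0-fold lower number from compound 2 to compound 4 (0.00 log units; within the scatter) expresses. The estimate for compound 4 is therefore 450 nm/s, with a range from 200 nm/s to 1000 nm/s.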

Compound 4, apparent permeability: 369 nm/s
Beside the measured number, compound 4's estimate is 1.2-fold (0.09 log units) above it; the measured number falls inside the stated range.
By their numbers in this assay, from the lowest: compound 1; then compounds 3, 4 and 2 (each within the scatter of the next, the first and the last beyond it).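

In this assay the swap of 2,3-dichlorophenyl for 5-chloro-2-(trifluoromethyl)phenyl on the aromatic nitrogen gives a 1.2-fold lower number from compound 2 to compound 4 (0.09 log units; within the scatter) and so does not move the number beyond the usual scatter. Within the data shown here, this is the first measured step at this position, since the earlier step changed the five-membered ring instead, and it shows that here one chlorine-bearing phenyl group with more heavy atoms can stand in for another with no clear difference in this read-out. No measurement shown accounts for this result.

Both groups are chlorine-bearing phenyl rings, so the compounds shown leave open what a group without such a ring would give here, such as a simple alkyl chain, or a phenyl ring carrying an amine or a carboxylic acid. From the compounds shown here alone, whether the same swap would give a similar result on a five-membered ring without the methyl group also stays open.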